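This account rests on a few compounds, and the source may have more. Where it says the series, first, only, none or still open, it means among the compounds named here.

Notes on the series. Compound 2 `C#Cc1cn([C@@H]2O[C@H](CO)[C@@H](O)[C@H]2O)c2ncnc(N(C)C)c12` carries an ethynyl group on its core; in a functional assay on HCT-116 cells (Homo sapiens), read by MTT assay, with a stated time of 72 h (a lower number here means a stronger inhibitor, a higher number a weaker inhibitor), compound 2 gives 290 nM. Compound 1 `CN(C)c1ncnc2c1c(-c1ccoc1)cn2[C@@H]1O[C@H](CO)[C@@H](O)[C@H]1O` differs from compound 2 by one change, (furan-3-yl in place of ethynyl on an aromatic carbon). In this assay compound 1 gives only a limit of the assay, > 20000 nM. The step of an at least 68-fold higher number from compound 2 to compound 1 (1.83 log units; beyond the scatter) is therefore known only as a lower bound, because its upper end is hidden by the limit of > 20000 nM in this assay, at which 2 of the 3 values shown sit.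

Compound 3 `C#Cc1cn([C@@H]2O[C@H](CO)[C@@H](O)[C@H]2O)c2nc(N)nc(OC)c12` keeps the ethynyl group on a different core; how the two cores of compound 3 and compound 2 differ is not broken down here. In this assay compound 3 gives only a limit of the assay, > 20000 nM.

Compound 4 `COc1nc(N)nc2c1c(-c1ccoc1)cn2[C@@H]1O[C@H](CO)[C@@H](O)[C@H]1O` is not yet measured in this assay. It differs from compound 3 by furan-3-yl in place of ethynyl on an aromatic carbon, which is the same change as that made from compound 2 to compound 1, at the same place. That earlier step, an at least 68-fold higher number from compound 2 to compound 1 (1.83 log units; beyond the scatter), was large, and compound 3 already gives no number but a limit. The step from compound 3 to compound 4 is thus expected to be a step that the limit leaves unreadable from compound 3 to compound 4, a size that cannot be fixed from a starting limit. Compound 4 is expected to give about 40000 nM in this assay, most probably again as a limit rather than a number, in the range 20000 nM to 200000 nM.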

Compound 4, half-maximal inhibitory concentration: > 20000 nM
Compound 4 gave a limit, no number; the forecaster's own chance of this, stated with the estimate: 95%; the middle value lies beyond the limit too.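

In this assay, compound 3 and compound 4 each stay at a limit of the assay and give no number, so no step between them can be read: the limit of > 20000 nM in this assay, at which 3 of the 4 values shown sit.

The compounds shown leave open how furan-3-yl compares with ethynyl on the core shared by compound 3 and compound 4, and whether any compound on that core gives a readable number in this assay.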